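The source may hold more compounds than are shown below. What is called first, only, known or untested is meant among the compounds shown, and "the series" means these compounds.

In a functional assay on CCRF-CEM cells (Homo sapiens) for inhibition, read by cell counting, with a stated time of 3 days (a higher number here means a weaker inhibitor, a lower number a stronger inhibitor), compound 1 `CCc1ccc(-c2nn3cc(-c4cccc(N)c4)nc3s2)cc1` gives 22000 nM. Compound 2 `CCOc1ccc(-c2nn3cc(-c4cccc(N)c4)nc3s2)cc1` gives only a limit of the assay, > 250000 nM. Compound 3 `COc1ccc(-c2nn3cc(-c4cccc(N)c4)nc3s2)cc1OC` gives 14000 nM.

Compound 3 therefore holds the lowest of the two numbers, with compound 1 nearest and within the scatter. Compound 4 `COc1ccc(-c2nn3cc(-c4cccc(N)c4)nc3s2)cc1` differs from compound 3 by hydrogen in place of methoxy on an aromatic carbon. Among the measured compounds shown here, the single measured step, an at least 11-fold higher number from compound 1 to compound 2 (1.05 log units; beyond the scatter), exchanges ethyl for ethoxy and does not remove a methoxy, so it bears on this change only loosely; it does show that one change on this ring can carry the number to the limit of > 250000 nM in this assay, at which 1 of the 3 values shown sits. Compound 4 is expected to be weaker than compound 3, at an estimated 60000 nM, between 15000 nM and 250000 nM. The expected step is a 4.3-fold higher number from compound 3 to compound 4 (0.63 log units; beyond the scatter).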

Compound 4, half-maximal inhibitory concentration: >= 250000 nM
Compound 4: only a limit was reported (the forecaster's own chance of this, stated with the estimate: 25%); middle value at least 4.1-fold (0.61 log units) away from the limit.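

Hydrogen in place of the methoxy ortho to a methoxy group gives an at least 17-fold higher number from compound 3 to compound 4 (1.25 log units; beyond the scatter) and so shows that this position matters in this series. Methoxy in place of ethyl gives an at least 11-fold higher number from compound 1 to compound 4 (1.05 log units; beyond the scatter) and extends what the ethoxy of compound 2 showed to a shorter group. The step between compound 2 and compound 4 cannot be read, and the value of compound 4 is itself a limit: the limit of >= 250000 nM in this assay, at which 1 of the 4 values shown sits.

As far as these compounds go, it remains open whether an amine or a longer chain at this position would keep the number near that of compound 3. From the compounds shown here alone, how far compound 4 lies beyond its limit also remains open.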